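This account rests on a few compounds, and the source may have more. Where it says the series, first, only, none or still open, it means among the compounds named here.

In an in vivo ADME assay on the whole organism (strain Sprague-Dawley) for pharmacokinetics, with Rattus norvegicus as the target (on this read-out higher numbers stand for higher oral bioavailability and lower numbers for lower oral bioavailability), compound 3 `CC(C)C[C@@]1(C(=O)O)C[C@H](C(N)=O)[C@H](c2nccs2)N1C(=O)c1ccc(C(C)(C)C)cc1` gives 2%. Compound 1 `COc1cc(C(=O)N2[C@@H](c3nccs3)[C@@H](C(N)=O)C[C@@]2(CC(C)C)C(=O)O)ccc1C(C)(C)C` gives 0.6% and compound 2 `CC(C)C[C@@]1(C(=O)O)C[C@H](C(N)=O)[C@H](c2nccs2)N1C(=O)c1ccc(C(C)(C)C)c(Cl)c1` gives 5%, so all three lie within the scatter of one another and cannot be ranked. Compound 4 `CC(C)C[C@@]1(C(=O)O)C[C@H](C(N)=O)[C@H](c2nccs2)N1C(=O)c1ccc(C(C)(C)C)c(Br)c1` differs from compound 3 in one place: bromo in place of hydrogen on an aromatic carbon, ortho to a tert-butyl group. Going by the values given here, two measured steps bear on this change. Hydrogen in place of chloro gives a number 3 percentage points lower from compound 2 to compound 3 (within the scatter), and hydrogen in place of methoxy gives a number 1.4 percentage points higher from compound 1 to compound 3 (within the scatter). Both are small and within the scatter, so the bromo swap is expected to produce no real shift in this assay, only an expected a number 3 percentage points higher from compound 3 to compound 4 (within the scatter). The estimated value for compound 4 is 5%, with an expected range of 1% to 15%.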

Compound 4, oral bioavailability: 2%
The estimate for compound 4 lay 3 percentage points above the measured number; the measured number falls inside the stated range.
By their numbers in this assay, from the lowest: compounds 1, 3, 4 and 2 (each within the scatter of the next).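

In this assay, putting bromo on this aromatic carbon, ortho to a tert-butyl group, gives no change at the digits printed from compound 3 to compound 4 (within the scatter); replacing the other two groups gives a number 3 percentage points lower from compound 2 to compound 4 (within the scatter) and a number 1.4 percentage points higher from compound 1 to compound 4 (within the scatter). Hydrogen, methoxy, chloro and bromo at this place therefore all lie within the scatter of one another, so this read-out cannot tell the four compounds apart. No available measurement offers an explanation for this result. On these data alone, whether an amine or a carboxylic acid at this place would give a step beyond the scatter remains open.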